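From Nitro to Trifluoromethyl on a Shared Core

This account rests on a few compounds, and the source may have more. Where it says the series, first, only, none or still open, it means among the compounds named here.

In a physicochemical assay for solubility, in phosphate buffer, at pH 7.4 (on this read-out higher numbers stand for higher solubility and lower numbers for lower solubility), compound 1 `CCOC(=O)c1c(-c2cccc(C)c2)[nH]c2cc(OC)ccc2c1=O` gives 48000 nM and compound 2 `CCOC(=O)c1c(-c2cccc([N+](=O)[O-])c2)[nH]c2cc(OC)ccc2c1=O` gives 13000 nM which is the lower of the two numbers. Within the data shown here, the one measured step of a 3.7-fold lower number from compound 1 to compound 2 (0.57 log units; beyond the scatter) puts nitro in place of methyl on an aromatic carbon and is modest. Among the measured compounds shown here, compound 3 `CCOC(=O)c1c(-c2cccc(C(F)(F)F)c2)[nH]c2cc(OC)ccc2c1=O` has trifluoromethyl in place of nitro on an aromatic carbon and no measured compound carries that group. That single step is therefore a weak guide, and the estimated step of a 1.2-fold higher number from compound 2 to compound 3 (0.06 log units; within the scatter) is expected to stay within the scatter. Compound 3 is expected at 15000 nM with an estimated range of 6000 nM to 36000 nM in this buffer.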

Compound 3, solubility: 19000 nM
Compound 3: the middle estimate sits 1.3-fold (0.10 log units) below what was measured; the measured number falls inside the stated range.
By their numbers in this assay, from the lowest: compounds 2 and 3 (each within the scatter of the next); then compound 1.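

In this assay, a 1.5-fold higher number from compound 2 to compound 3 (0.16 log units; within the scatter) stays within the scatter, so trifluoromethyl and nitro on this aromatic carbon cannot be told apart. By contrast, a 2.5-fold lower number from compound 1 to compound 3 (0.40 log units; beyond the scatter) lies beyond the scatter, and compound 1 with its methyl now stands above both of the other compounds, not just compound 2. Nothing available explains why these groups fall this way. What the compounds shown leave open is whether an amine or a carboxylic acid at this place would give a number apart from these three. They also leave open whether the gap to methyl would hold on a core with another group in place of the ethyl ester.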